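Lengthening a methyl to an ethyl

This account rests on a few compounds, and the source may have more. Where it says the series, first, only, none or still open, it means among the compounds named here.

Measured in a functional assay on HCT-116 cells (Homo sapiens) for cytotoxicity, with a stated time of 48 h; a higher number here means a weaker inhibitor of growth, a lower number a stronger inhibitor of growth:
- Compound 1 `Cc1cc(-c2cc(N3C[C@H](O)[C@@H](O)C3)ccc2O)nc(N)n1`: 400 nM
- Compound 2 `Nc1nc(NC2CCCCC2)cc(-c2cc(N3C[C@H](O)[C@@H](O)C3)ccc2O)n1`: 900 nM
- Compound 3 `Nc1nc(-c2cc(N3C[C@H](O)[C@@H](O)C3)ccc2O)cc(C2CCCNC2)n1`: > 10000 nM, which is a limit of the assay

Compound 1 has the lower of the two actual numbers, so it is the strongest growth inhibitor of the three. Compound 4 `CCc1cc(-c2cc(N3C[C@H](O)[C@@H](O)C3)ccc2O)nc(N)n1` keeps the core of compound 1 and turns its methyl into ethyl: methyl in place of hydrogen on a saturated chain carbon bound to an aromatic carbon. Two measured steps replace that same methyl. Cyclohexylamino gave a 2.3-fold higher number from compound 1 to compound 2 (0.35 log units; beyond the scatter), a modest change, and piperidin-3-yl gave an at least 25-fold higher number from compound 1 to compound 3 (1.39 log units; beyond the scatter), a large one. Both of those groups bring a ring, whereas this change adds only a methyl and no ring. In this assay, little or no rise is therefore expected. The expected step is a 1.3-fold higher number from compound 1 to compound 4 (0.10 log units; within the scatter). For compound 4 the estimated value is 500 nM. The expected range for compound 4 runs from 220 nM to 1200 nM.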

Compound 4, concentration for 50% growth inhibition: 1000 nM
Compound 4: middle estimate off by 2.0-fold (0.30 log units), on the low side; the range from low to high includes it.
By their numbers in this assay, from the lowest: compound 1; then compounds 2 and 4 (each within the scatter of the next). At a limit, above all of these: compound 3.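

In this assay, adding a single methyl, with no ring, already gives a 2.5-fold higher number from compound 1 to compound 4 (0.40 log units; beyond the scatter) and so costs activity at this position. Ethyl and cyclohexylamino cannot be told apart, with a 1.1-fold higher number from compound 2 to compound 4 (0.05 log units; within the scatter) between them, which shows that a ring is not needed for a loss of this kind. Piperidin-3-yl stands apart, with an at least 10-fold lower number from compound 3 to compound 4 (1.00 log units; beyond the scatter) as a bound only, since compound 3 sits at a limit: the limit of > 10000 nM in this assay, at which 1 of the 4 values shown sits.

From the compounds shown here alone, whether the rise continues with a longer chain such as propyl remains open, as does the effect of an amine on that saturated chain carbon.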